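This account rests on a few compounds, and the source may have more. Where it says the series, first, only, none or still open, it means among the compounds named here.

In a functional assay on A549 cells (Homo sapiens) for cytotoxicity, read by MTT assay, with a stated time of 72 h (a higher number here means a weaker inhibitor, a lower number a stronger inhibitor), compound 2 `O=C1CC(c2c(-c3ccc[nH]3)[nH]c3ccccc23)C(=O)N1` gives 8000 nM, while compound 1 `COc1ccc2[nH]c(-c3ccc[nH]3)c(C3CC(=O)NC3=O)c2c1` gives 4000 nM. Among the measured compounds shown here, these are the only two measurements available, and they lie within the scatter of each other, so compound 2 cannot be separated from compound 1 on these numbers. Compound 3 `Cc1ccc2[nH]c(-c3ccc[nH]3)c(C3CC(=O)NC3=O)c2c1` keeps the shared core of compound 2 and differs from it by methyl in place of hydrogen on an aromatic carbon. This carbon belongs to a six-membered aromatic ring of carbon only, part of a fused system of two rings. For the measured compounds named here, only one measured step bears on this change: hydrogen in place of methoxy on an aromatic carbon, which gave a 2.0-fold higher number from compound 1 to compound 2 (0.30 log units; within the scatter) and stayed within the scatter. Going by the values given here, no measured step involves a methyl group, so this comparison is only a loose guide. On that evidence, no shift beyond the scatter is expected in this assay, though a slight drift toward the value of compound 1 4000 nM is possible. The expected step is a 1.5-fold lower number from compound 2 to compound 3 (0.16 log units; within the scatter). For compound 3 the estimated value is 5500 nM, with an expected range from 2500 nM to 12000 nM.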

Compound 3, half-maximal inhibitory concentration: 20000 nM
Compound 3: middle estimate off by 3.6-fold (0.56 log units), on the low side; measured number outside the range, above it.
By their numbers in this assay, from the lowest: compounds 1 and 2 (each within the scatter of the next); then compound 3.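

In this assay, among the compounds shown here, methyl in place of hydrogen on this aromatic carbon of the six-membered ring gives a 2.5-fold higher number from compound 2 to compound 3 (0.40 log units; beyond the scatter) and is the first change here to lie beyond the scatter, though the step is modest. The exchange of methoxy for methyl on the same carbon gives a 5.0-fold higher number from compound 1 to compound 3 (0.70 log units; beyond the scatter) and so shows that the assay does respond to the group placed at this position, and that methyl and methoxy cannot be treated as equivalent here, even though hydrogen and methoxy could not be separated. Nothing available bears on why methyl moves the number in this direction. 

With only hydrogen, methyl and methoxy at this carbon, the three compounds give no trend that could be extended to other groups, and they do not show whether a longer chain such as ethyl would carry the number further in the direction of methyl. They also leave open where a halogen such as chlorine, an amine or a carboxylic acid at the same carbon would fall relative to compound 1 and compound 3.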